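Swapping Trifluoromethyl for Benzoyl in Two Related Cores

The source may hold more compounds than are shown below. What is called first, only, known or untested is meant among the compounds shown, and "the series" means these compounds.

Of the compounds shown here, three have been measured in an ADME assay on MONO-MAC-6 cells (Homo sapiens) for cytotoxicity, read by MTT assay, with a stated time of 16 h; a lower number here means a stronger inhibitor, a higher number a weaker inhibitor. Compound 1 `O=C(Nc1ccc(C(F)(F)F)cc1)c1cc(Br)ccc1O` gives 7600 nM in this assay. Compound 2 `O=C(c1ccccc1)c1ccc(NC(=O)c2cc(Br)ccc2O)cc1` shares the core of compound 1 and differs from it only by benzoyl in place of trifluoromethyl on an aromatic carbon; in this assay compound 2 gives 21800 nM. That single change made a 2.9-fold higher number from compound 1 to compound 2 (0.46 log units; beyond the scatter).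

Compound 3 `O=C(NCCCCl)Oc1ccc(Cl)cc1C(=O)Nc1ccc(C(F)(F)F)cc1` is built on a different core, and the difference between the core of compound 1 and the core of compound 3 is not broken down here. In this assay, among the measured compounds shown here, compound 3 gives 8800 nM, a number that sits close to the one for compound 1 and clearly apart from the one for compound 2.

Compound 4 `O=C(NCCCCl)Oc1ccc(Cl)cc1C(=O)Nc1ccc(C(=O)c2ccccc2)cc1` has not yet been measured. For the measured compounds named here, it differs from compound 3 by benzoyl in place of trifluoromethyl on an aromatic carbon, which is the same change, at the same kind of place, as the one from compound 1 to compound 2. Going by the values given here, the expectation for compound 4 therefore rests on the only measured example of this change, the step of a 2.9-fold higher number from compound 1 to compound 2 (0.46 log units; beyond the scatter), and on the starting value of compound 3, 8800 nM. With one example only, the expected size of the step from compound 3 to compound 4 is estimated as a 2.8-fold higher number from compound 3 to compound 4 (0.45 log units; beyond the scatter). The estimated value for compound 4 in this assay is 25000 nM. For compound 4 the estimate is expected to fall between 12000 nM and 55000 nM.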

Compound 4, half-maximal inhibitory concentration: 16100 nM
For compound 4 the middle estimate is 1.6-fold (0.19 log units) above the measured one, within the range that was stated.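

In this assay, placing benzoyl where trifluoromethyl stood on the core of compound 3 gives a 1.8-fold higher number from compound 3 to compound 4 (0.26 log units; within the scatter), a step that cannot, on its own, be told apart from the ordinary variation between repeated measurements. Comparing the size of this step with the one seen on the other core gives no sign that the two differ: the same change on two cores in this assay, a 2.9-fold higher number (0.46 log units; beyond the scatter) from compound 1 to compound 2 and a 1.8-fold higher number (0.26 log units; within the scatter) from compound 3 to compound 4, 1.6-fold (0.20 log units) apart, within the scatter of two such steps This shows that the two cores give steps that cannot be separated by these measurements, but it does not show that the change has exactly the same size on both, and with only two matched pairs it says nothing firm about any other core in this series.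

The compounds shown leave open how an amine or a carboxylic acid would behave in place of trifluoromethyl or benzoyl on that same aromatic carbon, on either core. They also leave open whether a longer chain in place of the chlorine-bearing chain shared by compound 3 and compound 4 would alter the size of the step from trifluoromethyl to benzoyl.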